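This account rests on a few compounds, and the source may have more. Where it says the series, first, only, none or still open, it means among the compounds named here.

Three compounds have been measured in an assay on isolated protein for inhibition of matrix metalloproteinase-9 (Homo sapiens), read by fluorescence; a lower number here means a stronger inhibitor, a higher number a weaker inhibitor:

compound 1, `COc1ccc(S(=O)(=O)N2C[C@H](NC(=O)CCCNC(=O)OC(C)(C)C)C[C@@H]2C(=O)NO)cc1`, gives 49 nM;
compound 2, `COc1ccc(S(=O)(=O)N2C[C@H](NC(=O)CCCN)C[C@@H]2C(=O)NO)cc1`, gives 53 nM;
compound 3, `COc1ccc(S(=O)(=O)N2C[C@H](NC(=O)[C@H](CCCN)NC(=O)OC(C)(C)C)C[C@@H]2C(=O)NO)cc1`, gives 3420 nM.

Compound 3 stands at the highest number of the three, meaning it is the weakest inhibitor among them. Its gap to compound 2, the nearest of the other two, lies well beyond the scatter of repeated measurements, and its gap to compound 1 is slightly larger still. Compound 1 and compound 2, for their part, sit so close together that no order can be read between them.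

Compound 4, `COc1ccc(S(=O)(=O)N2C[C@H](NC(=O)[C@@H](N)CCCN)C[C@@H]2C(=O)NO)cc1`, is built from compound 3 by one change: hydrogen in place of tert-butoxycarbonyl on an amine nitrogen. The same kind of change has been measured once already, between compound 1 and compound 2, where it gave a 1.1-fold higher number from compound 1 to compound 2 (0.03 log units; within the scatter). Among the measured compounds shown here, that single step is the only guide available here, and it points to no movement beyond the scatter. The expected step in this assay is therefore a 1.0-fold lower number from compound 3 to compound 4 (0.00 log units; within the scatter), which is to say essentially none. On that basis compound 4 is estimated at 3400 nM, with a plausible range from 1500 nM to 8000 nM.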

Compound 4, half-maximal inhibitory concentration: 154 nM
Estimate against measurement, compound 4: 22-fold (1.34 log units) above; the whole stated range lies above it.
By their numbers in this assay, from the lowest: compounds 1 and 2 (each within the scatter of the next); then compound 4; then compound 3.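

In this assay, hydrogen in place of tert-butoxycarbonyl on an amine nitrogen has no single effect, and what it does depends on the compound that carries it: the same change on two cores in this assay, a 1.1-fold higher number (0.03 log units; within the scatter) from compound 1 to compound 2 and a 22-fold lower number (1.35 log units; beyond the scatter) from compound 3 to compound 4, 24-fold (1.38 log units) apart, beyond the scatter of two such steps

On the core of compound 3 the change is large, a 22-fold lower number from compound 3 to compound 4 (1.35 log units; beyond the scatter), yet it does not bring the number all the way back to those of the two compounds with simpler chains, as the modest steps of a 2.9-fold higher number from compound 2 to compound 4 (0.46 log units; beyond the scatter) and a 3.1-fold higher number from compound 1 to compound 4 (0.50 log units; beyond the scatter) show. Swapping in 1,4-diaminobutyl on the carbonyl carbon therefore costs only a little when its amines are free, and most of the high number of compound 3 goes with the tert-butoxycarbonyl on that amine nitrogen.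

On these data alone, what remains open is whether a smaller group on the same nitrogen, such as acetyl, would read like tert-butoxycarbonyl or like hydrogen. As far as these compounds go, it is also open whether a longer chain carrying the two amines, or a carboxylic acid in place of the end amine, would close or widen the remaining gap.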